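Swapping the 2-carboxyethyl group of compound 3

The source may hold more compounds than are shown below. What is called first, only, known or untested is meant among the compounds shown, and "the series" means these compounds.

In a functional assay on FaDu cells (Homo sapiens) for cytotoxicity, read by MTT assay, with a stated time of 72 h (a higher number here means that more compound is tolerated, a lower number that less compound is tolerated), compound 1 `COc1ccc(NC(=O)C(=O)c2cn(C(C)C)c3ccccc23)cn1` gives a true number of 85 nM. Compound 2 `COc1ccc(NC(=O)C(=O)c2cn(CC(C)(C)OC)c3ccccc23)cn1` gives > 10000 nM, which is a limit of the assay and not a number. Compound 3 `COc1ccc(NC(=O)C(=O)c2cn(CCC(=O)O)c3ccccc23)cn1` gives > 10000 nM, which is also a limit. Compound 3 therefore stands at the limit of > 10000 nM in this assay, at which 2 of the 3 values shown sit.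

Compound 4 `COCC(C)n1cc(C(=O)C(=O)Nc2ccc(OC)nc2)c2ccccc21` differs from compound 3 in one place: 1-(methoxymethyl)ethyl in place of 2-carboxyethyl on an aromatic nitrogen. The 1-(methoxymethyl)ethyl group replaces the 2-carboxyethyl group on an aromatic nitrogen.

Among the compounds with values here, no measured step matches this change exactly, but three bear on it. Replacing isopropyl with 2-carboxyethyl gave an at least 110-fold higher number from compound 1 to compound 3 (2.07 log units; beyond the scatter), and replacing it with 2-methoxy-2-methylpropyl gave an at least 110-fold higher number from compound 1 to compound 2 (2.07 log units; beyond the scatter). Both steps are large, so this position can matter greatly. The remaining comparison, a step that the two limits leave unreadable from compound 2 to compound 3, gives no size.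

The entering group looks closer to the isopropyl group of compound 1, at 85 nM, than the leaving group does. Against that, the methoxy-bearing chain of compound 2 shows an at least 110-fold higher number from compound 1 to compound 2 (2.07 log units; beyond the scatter), so a partial recovery seems the safest expectation. A sizeable move to a lower number is expected, and the estimated change is an at least 14-fold lower number from compound 3 to compound 4 (1.15 log units; beyond the scatter). The expected value for compound 4 is 700 nM, with an estimated range of 80 nM to 10000 nM.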

Compound 4, concentration lethal to 50% of the cells in the FaDu assay: 12 nM
For compound 4 the middle estimate is 58-fold (1.77 log units) above the measured one; measured number below the stated range.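

This change shows that the chain on the aromatic nitrogen does not have to be a plain isopropyl group, and that a methoxy group on it is not harmful in itself: in the FaDu assay, where a lower number means that less compound is tolerated, the step to the 1-(methoxymethyl)ethyl group is an at least 830-fold lower number from compound 3 to compound 4 (2.92 log units; beyond the scatter), and against the other methoxy-bearing chain it is an at least 830-fold lower number from compound 2 to compound 4 (2.92 log units; beyond the scatter). Since 2-methoxy-2-methylpropyl and 1-(methoxymethyl)ethyl both carry a methoxy group, the arrangement of the chain counts here, and not just the presence of that group. The earlier compounds shown here showed only rises from isopropyl, whereas methoxy in place of hydrogen on a saturated chain carbon, two bonds along the chain from an aromatic nitrogen, now gives a 7.1-fold lower number from compound 1 to compound 4 (0.85 log units; beyond the scatter).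

As far as these compounds go, the two largest steps start from limits and not from numbers, so their true sizes stay open. In the FaDu assay compound 2 and compound 3 both sit at a limit: the limit of > 10000 nM in the FaDu assay, at which 2 of the 4 values shown sit.

In a physicochemical assay for solubility, in phosphate buffer, at pH 7.4 (on this read-out lower numbers stand for lower solubility and higher numbers for higher solubility), compound 3 gives <= 200000 nM, which is a limit of the assay and not a number. In the physicochemical assay compound 4 gives 40000 nM. The remaining steps in the FaDu assay and the physicochemical assay cannot be read.

From the compounds shown here alone, what a hydroxyl group, an amine or a longer chain would do in place of the methoxy-bearing chain also remains open.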